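A few compounds are considered here, and "the series" means these few. Any claim that something is new, unique, unknown or untested is made for them only; others in the source may bear on it.

Compound 1, `O=C1CCCC/C1=C\c1ccc(OC(=O)c2ccc(Cl)cc2)cc1`, gives 25500 nM in a functional assay on P388 cells (Mus musculus); on this read-out higher numbers stand for weaker inhibition and lower numbers for stronger inhibition. Compound 3, `CN(C)CC1CCC/C(=C\c2ccc(OC(=O)c3ccc(Cl)cc3)cc2)C1=O`, gives 425 nM in this assay. For compound 2, `COc1ccc(C(=O)Oc2ccc(/C=C3\CCCCC3=O)cc2)cc1`, this assay reports only a limit, > 50000 nM, and no number.

Two single changes connect these compounds. The first, (methoxy in place of chloro on an aromatic carbon), brought an at least 1.9-fold higher number from compound 1 to compound 2 (0.29 log units; that floor lies within the scatter); because the value of compound 2 is the limit of > 50000 nM in this assay, at which 1 of the 3 values shown sits, only a floor for that step is known. The second, ((dimethylamino)methyl in place of hydrogen on a saturated ring carbon), brought a 60-fold lower number from compound 1 to compound 3 (1.78 log units; beyond the scatter), by far the larger effect seen here.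

Compound 4, `COc1ccc(C(=O)Oc2ccc(/C=C3\CCCC(CN(C)C)C3=O)cc2)cc1`, is not yet measured. It differs from compound 3 by methoxy in place of chloro on an aromatic carbon, the same change that turned compound 1 into compound 2, made at the same place. Starting from compound 3, the expected step is a 3.5-fold higher number from compound 3 to compound 4 (0.55 log units; beyond the scatter), a weakening of similar order to an at least 1.9-fold higher number from compound 1 to compound 2 (0.29 log units; that floor lies within the scatter), though that earlier step is known only as a floor, which leaves the true size open. Compound 4 is therefore expected to give about 1500 nM, estimated to fall between 500 nM and 5000 nM.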

Compound 4, half-maximal inhibitory concentration: 332 nM
The estimate for compound 4 lay 4.5-fold (0.65 log units) above the measured number; measured number below the stated range.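

In this assay, replacing chloro with methoxy on the core that carries the (dimethylamino)methyl group brought a 1.3-fold lower number from compound 3 to compound 4 (0.11 log units; within the scatter), so this pair shows no real difference. This does not show that the change behaves differently on the two cores, nor that it behaves alike, since its size on the core of compound 1 is known only as a floor: the same change on two cores in this assay, an at least 1.9-fold higher number (0.29 log units; that floor lies within the scatter) from compound 1 to compound 2 and a 1.3-fold lower number (0.11 log units; within the scatter) from compound 3 to compound 4; the limit leaves it open whether they differ The (dimethylamino)methyl group, by contrast, brought an at least 150-fold lower number from compound 2 to compound 4 (2.17 log units; beyond the scatter), a figure that rests on a limit for compound 2, and a large lowering appears on both cores: the same change on two cores in this assay, a 60-fold lower number (1.78 log units; beyond the scatter) from compound 1 to compound 3 and an at least 150-fold lower number (2.17 log units; beyond the scatter) from compound 2 to compound 4; the limit leaves it open whether they differ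

The compounds shown cover only chloro and methoxy at this place on the aromatic ring, so it stays open how a carboxylic acid or a simple amine there would fare on either core. On these data alone, it also stays open whether a different amine, such as a diethylamino group, or a longer chain between the amine and the saturated ring would keep the large lowering.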